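The compounds below may be only part of what the source reports. "The series", "measured", "known", "first", "only" and "open" are said of these compounds alone.

In a functional assay on NCI-H460 cells (Homo sapiens) for inhibition, read by sulforhodamine B assay, with a stated time of 72 h (a higher number here means a weaker inhibitor, a lower number a stronger inhibitor), compound 1 (`CCNC(=O)c1nnn(-c2cc(C(C)C)c(O)cc2O)c1-c1ccc(CN2CCCC2)cc1`) gives 3 nM and compound 2 (`CCNC(=O)c1nnn(-c2cc(C(C)C)c(O)cc2O)c1-c1ccc(CN2CCC(N(C)C)CC2)cc1`) gives 120 nM as the higher of the two numbers, which puts compound 2 at the weaker end of this pair. Compound 3 (`CCNC(=O)c1nnn(-c2cc(C(C)C)c(O)cc2O)c1-c1ccc(CNCCCN(CC)CC)cc1`) differs from compound 2 by (3-(diethylamino)propyl)amino in place of 4-(dimethylamino)piperidin-1-yl on a saturated chain carbon bound to an aromatic carbon in the series, that is (3-(diethylamino)propyl)amino in place of 4-(dimethylamino)piperidin-1-yl on a saturated chain carbon bound to an aromatic carbon. Within the data shown here, the one measured step at this place is a 40-fold higher number from compound 1 to compound 2 (1.60 log units; beyond the scatter) and it is large, beyond the scatter. That step shows that a change of group here can move the number far, but it does not cover the entering group, so the direction stays uncertain. A modest move toward a lower number is expected, and the estimated step is a 2.0-fold lower number from compound 2 to compound 3 (0.30 log units; within the scatter) with wide uncertainty. The estimate for compound 3 is 60 nM within an expected range of 12 nM to 300 nM in this assay series.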

Compound 3, half-maximal inhibitory concentration: 412 nM
For compound 3 the middle estimate is 6.9-fold (0.84 log units) below the measured one; measured number outside the range, above it.
By their numbers in this assay, from the lowest: compound 1; then compound 2; then compound 3.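

In this assay, replacing 4-(dimethylamino)piperidin-1-yl with the ring-free (3-(diethylamino)propyl)amino, with the heavy-atom count unchanged, gives a 3.4-fold higher number from compound 2 to compound 3 (0.54 log units; beyond the scatter), so this position responds to a change of group even without a change in size by that count. Measured against pyrrolidin-1-yl, the same group gives a 140-fold higher number from compound 1 to compound 3 (2.14 log units; beyond the scatter), the largest step among the three compounds, and pyrrolidin-1-yl remains the group with the lowest number at this place. No measurement bears on why the number moves with these changes.

Compound 3 loses the ring and gains a hydrogen-bond donor in the same step, so the two changes cannot be separated here. Going by these compounds, how a plain piperidin-1-yl or a morpholin-4-yl would stand on this saturated chain carbon remains open.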